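This account rests on a few compounds, and the source may have more. Where it says the series, first, only, none or still open, it means among the compounds named here.

Compound 1 `CC(C)=CCC1Cc2c(O)cc(=O)n(CCCO)c2CC1(C)C`: 25.6%
Compound 2 `CC(C)=CCC1Cc2c(OCCCNS(=O)(=O)c3ccc([N+](=O)[O-])cc3)cc(=O)n(CCCO)c2CC1(C)C`: 47.7%
Compound 3 `CC(C)=CCC1Cc2c(OC(=O)Nc3ccc(F)cc3)cc(=O)n(CCCO)c2CC1(C)C`: 71.2%

Of the compounds shown here, three sharing one core have been measured in a functional assay on PANC-1 cells (Homo sapiens) for inhibition, read by MTT assay, with a stated time of 24 h, tested at 10 uM; a lower number here means less inhibition, a higher number more inhibition at the concentration tested (going by the name of the read-out). Compound 1 stands lowest of the three with 25.6%; compound 2 lies above it, and compound 3, at 71.2%, lies furthest above it, both gaps beyond the scatter.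

Compound 4 `CC(C)=CCC1Cc2c(OC(=O)Nc3ccc(F)c(F)c3)cc(=O)n(CCCO)c2CC1(C)C` has not yet been measured. It differs from compound 1 in one place: (3,4-difluorophenyl)carbamoyl in place of hydrogen on an oxygen on an aromatic ring. Within the data shown here, the one measured step that speaks to this change is the one to compound 3, where a (4-fluorophenyl)carbamoyl group took the place of the same hydrogen on the same oxygen: a number 45.6 percentage points higher from compound 1 to compound 3 (beyond the scatter), a large rise. Compound 4 carries a (3,4-difluorophenyl)carbamoyl group instead, differing from the group in compound 3 by one fluorine only, so a rise of similar size is expected, though its exact extent cannot be read from a single step. The step from compound 1 to compound 4 is therefore expected to be a number 42.4 percentage points higher from compound 1 to compound 4 (beyond the scatter). On that basis compound 4 is estimated to give 68% in this assay, with a likely range from 50% to 85%.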

Compound 4, a percentage reported as inhibition, at one concentration (the size of the read-out at that concentration, not a potency): 76.7%
Compound 4: the middle estimate sits 8.7 percentage points below what was measured; low and high end bracket the measured number.
By their numbers in this assay, from the lowest: compound 1; then compound 2; then compounds 3 and 4 (each within the scatter of the next).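

In this assay a second aryl carbamoyl group on the oxygen on the aromatic ring also brings a large gain, with a number 51.1 percentage points higher from compound 1 to compound 4 (beyond the scatter), so the rise is not tied to the (4-fluorophenyl)carbamoyl group alone. The extra fluorine makes no difference that can be read here: a number 5.5 percentage points higher from compound 3 to compound 4 (within the scatter), so the two fluorinated groups cannot be told apart in this assay. Nothing at hand explains why these groups give such a rise.

The compounds shown leave open whether fluorine matters at all, which a plain phenylcarbamoyl group or one carrying a chlorine or a methoxy group would test. They also leave open whether the aromatic ring is needed, which a butylcarbamoyl group on the same oxygen would test.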